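This account rests on a few compounds, and the source may have more. Where it says the series, first, only, none or still open, it means among the compounds named here.

Compound 2 `CCN(c1cccc(-c2ccccc2)c1)c1ccc(C#N)c(Cl)c1` carries a phenyl group on an aromatic carbon of its core. In a functional assay on VCaP cells (Homo sapiens) for antiproliferative activity, read by CCK-8 assay, with a stated time of 6 days (a higher number here means a weaker inhibitor, a lower number a stronger inhibitor), compound 2 gives "not determined" (no result reported), so there is no number to place it against the other compounds. Two related compounds were measured. Compound 1 `CCN(c1ccc(C#N)c(Cl)c1)c1cc(-c2ccccc2)ccc1C` reaches the limit of this assay rather than a number, > 30000 nM; (the limit of > 30000 nM in this assay, at which 1 of the 3 values shown sits). Compound 3 `CCN(c1ccc(C#N)c(Cl)c1)c1cc(C2=CCCCC2)ccc1C` gives 20000 nM in this assay. Among the compounds with values here, the only measured step, an at least 1.5-fold lower number from compound 1 to compound 3 (0.17 log units; that floor lies within the scatter), exchanges phenyl for cyclohex-1-en-1-yl and sits within the scatter, so the identity of that ring made little difference there. Compound 4 `CCN(c1cccc(-c2cncnc2)c1)c1ccc(C#N)c(Cl)c1` differs from compound 2 in pyrimidin-5-yl in place of phenyl on an aromatic carbon. That exchange is not the one measured, and compound 2 itself has no number, so no direction can be set for this assay with confidence; what the measured compounds do show is weak inhibition throughout. Compound 4 is therefore expected to give about 20000 nM in this assay, within a range from 5000 nM to 30000 nM.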

Compound 4, half-maximal inhibitory concentration: > 30000 nM
Compound 4 was reported as a limit; the forecaster's own chance of this, stated with the estimate: 45%; middle value at least 1.5-fold (0.17 log units) away from the limit.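

In this assay compound 4 reaches a limit rather than a number: the limit of > 30000 nM in this assay, at which 2 of the 4 values shown sit.

Within the data shown here, compound 2 has no result, so no step between compound 2 and compound 4 can be read. On these data alone, whether pyrimidin-5-yl in place of phenyl changes activity on this core stays open.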